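This account rests on a few compounds, and the source may have more. Where it says the series, first, only, none or still open, it means among the compounds named here.

Measured compounds:
compound 1 `COC(=O)c1c(F)cccc1-c1ccc(CCc2ncc(CC(C)(C)C)n2Cc2ccc(C(=O)O)cc2)cc1`: 3 nM
compound 2 `COC(=O)c1c(F)cccc1-c1ccc(CCc2ncc(CC(C)(C)C)n2CCO)cc1`: 21 nM

In an assay on cells for agonist activity at Bombesin receptor subtype-3 (Homo sapiens), read by HTRF and inositol phosphate accumulation, with a stated time of 1 h (a lower number here means that less compound is needed, a higher number that more compound is needed for the effect), compound 1 gives 3 nM and stands lowest of the two numbers; its nearest neighbour is compound 2 with 21 nM. For the measured compounds named here, the only measured step, a 7.0-fold higher number from compound 1 to compound 2 (0.85 log units; beyond the scatter), concerns the group on the saturated chain carbon bound to an aromatic nitrogen and is modest in size.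

Compound 3 `CC(C)(C)Cc1cnc(CCc2ccc(-c3cccc(F)c3C(=O)O)cc2)n1Cc1ccc(C(=O)O)cc1` differs from compound 1 by hydrogen in place of methyl on an oxygen next to a carbonyl group. Going by the values given here, the measured step leaves the methoxycarbonyl untouched, so it does not bear on this change; no measured pair informs the ester-to-acid exchange at this position. The expectation therefore rests on the structural change alone, and a step of no more than modest size in either direction is anticipated, with a wide range. For compound 3 the estimated value in this assay is 8 nM (range 2 nM to 40 nM), corresponding to an expected step of a 2.7-fold higher number from compound 1 to compound 3 (0.43 log units; beyond the scatter).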

Compound 3, half-maximal effective concentration: 12 nM
Compound 3: middle estimate off by 1.5-fold (0.18 log units), on the low side, and the stated range covers the measured number.
By their numbers in this assay, from the lowest: compound 1; then compounds 3 and 2 (each within the scatter of the next).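

In this assay, for the compounds shown here, the exchange of methoxycarbonyl for carboxy on the 3-fluoro-2-(methoxycarbonyl)phenyl group gives a 4.0-fold higher number from compound 1 to compound 3 (0.60 log units; beyond the scatter), the first reading of a change at this position. The step lies beyond the scatter and is modest, so the number at this position does depend on whether the methyl is present, while compound 3 with the free carboxy still reads 12 nM in this assay. Nothing on hand accounts for this step.

As far as these compounds go, whether the same exchange gives a step of similar size with the hydroxyethyl group of compound 2 on the aromatic nitrogen remains open. Going by these compounds alone, also open is how an ethyl ester, a primary amide or a hydroxymethyl group would read at this position, since methoxycarbonyl and carboxy are the only two groups compared here.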